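A Second Hydroxyl on the Side Chain

The source may report more compounds than this note shows. Statements on the series, on what has been measured and on what is new or still open speak of the compounds shown alone.

Three compounds share a core and differ only in the substituent on the nitrogen that joins the two aryl parts. Compound 1 `CC(C)CN(c1ccnc(Nc2ccc(C#N)cc2)n1)c1c(F)cc(-c2ccc(C#N)cc2)cc1F` carries an isobutyl chain, compound 2 `N#Cc1ccc(Nc2nccc(N(CC3CCCC3)c3c(F)cc(-c4ccc(C#N)cc4)cc3F)n2)cc1` a cyclopentylmethyl chain, and compound 3 `CC(O)CN(c1ccnc(Nc2ccc(C#N)cc2)n1)c1c(F)cc(-c2ccc(C#N)cc2)cc1F` a 2-hydroxypropyl chain. In an ADME assay on MT4 cells (Homo sapiens) for cytotoxicity, read by MTT assay, with a stated time of 5 days (a higher number here means that more compound is tolerated, a lower number that less compound is tolerated), compound 1 gives 241000 nM. Compound 2 reaches only a limit of this assay, > 247000 nM (the limit of > 247000 nM in this assay, at which 1 of the 3 values shown sits). Compound 3 gives 9800 nM, the lowest of the two numbers shown; its nearest neighbour is compound 1, and the step of a 25-fold lower number from compound 1 to compound 3 (1.39 log units; beyond the scatter). The change an at least 1.0-fold higher number from compound 1 to compound 2 (0.01 log units; that floor lies within the scatter), whereas the step of an at least 25-fold lower number from compound 2 to compound 3 (1.40 log units; beyond the scatter).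

Compound 4 `N#Cc1ccc(Nc2nccc(N(CC(O)CO)c3c(F)cc(-c4ccc(C#N)cc4)cc3F)n2)cc1` is not yet measured. It differs from compound 3 by hydroxy in place of hydrogen on a saturated chain carbon, two bonds along the chain from an oxygen on a saturated carbon. For the measured compounds named here, the two measured steps that introduce a hydroxy group, from compound 1 and from compound 2 to compound 3, each lowered the number strongly, so a further hydroxy group might move it again, though no measured pair adds a second hydroxy group and the direction is uncertain. The step from compound 3 to compound 4 is expected to be a 1.2-fold higher number from compound 3 to compound 4 (0.09 log units; within the scatter). Compound 4 is therefore expected to give about 12000 nM, within a range from 3000 nM to 60000 nM.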

Compound 4, half-maximal cytotoxic concentration: 19500 nM
Beside the measured number, compound 4's estimate is 1.6-fold (0.21 log units) below it, and the stated range covers the measured number.
By their numbers in this assay, from the lowest: compounds 3 and 4 (each within the scatter of the next); then compound 1. At a limit, above all of these: compound 2.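

This is the one pair shown that adds a second hydroxy group, and on this saturated chain carbon, two bonds along the chain from an oxygen on a saturated carbon, the addition stays within the scatter: a 2.0-fold higher number from compound 3 to compound 4 (0.30 log units; within the scatter). The large gap to the chains without a hydroxy group therefore remains with the 2,3-dihydroxypropyl chain in this assay, as a 12-fold lower number from compound 1 to compound 4 (1.09 log units; beyond the scatter) and an at least 12-fold lower number from compound 2 to compound 4 (1.10 log units; beyond the scatter) show, so among these compounds both hydroxylated chains stand well apart from the isobutyl and cyclopentylmethyl chains, and the second hydroxy group neither widens that gap beyond the scatter nor closes it. One of these two large steps starts from a limit and not from a number: the limit of > 247000 nM in this assay, at which 1 of the 4 values shown sits.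

The compounds shown leave open whether an amine, a carboxylic acid or a longer chain ending in a hydroxy group on this nitrogen would fall with the two hydroxylated chains or with the isobutyl chain. They also leave open whether a single hydroxy group placed at the end of the chain, as a 3-hydroxypropyl chain, would give a number of the same order.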